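The source may hold more compounds than are shown below. What is called first, only, known or untested is meant among the compounds shown, and "the series" means these compounds.

Three compounds share the same core and differ only in the group on a nitrogen on an aromatic ring. In a functional assay on MGC-803 cells (Homo sapiens) for cytotoxicity, read by MTT assay, with a stated time of 72 h (on this read-out higher numbers stand for weaker inhibition and lower numbers for stronger inhibition), compound 1 `CCCCCCCCCCCCNc1nc(SCc2ccc(C(F)(F)F)cc2)nc2ccccc12` gives > 50000 nM, which is a limit of the assay and not a number. Compound 2 `FC(F)(F)c1ccc(CSc2nc(Nc3ccccc3)c3ccccc3n2)cc1` gives 22200 nM in this assay. Compound 3 `FC(F)(F)c1ccc(CSc2nc(Nc3ccccc3Cl)c3ccccc3n2)cc1` gives > 50000 nM in this assay, again a limit rather than a number. Going by the values given here, the one measured step, an at least 2.2-fold higher number from compound 2 to compound 3 (0.35 log units; beyond the scatter), runs toward weaker inhibition. Compound 3 therefore stands at the limit of > 50000 nM in this assay, at which 2 of the 3 values shown sit, without an exact number of its own.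

Compound 4 `FC(F)(F)c1ccc(CSc2nc(Nc3cccc(Br)c3)c3ccccc3n2)cc1` has not yet been measured in this assay. It differs from compound 3 by 3-bromophenyl in place of 2-chlorophenyl on a nitrogen on an aromatic ring. Among the compounds with values here, no measured step exchanges one halogen-bearing phenyl for another, so the only step that bears on this change is the one from a plain phenyl to a halogen-bearing one, which was at least modest and went toward weaker inhibition. Since compound 3 has only a limit, the expected step is read as an at least 1.2-fold lower number from compound 3 to compound 4 (0.09 log units; that floor lies within the scatter), small and uncertain in either direction. Compound 4 is estimated to give about 40000 nM in this assay, somewhere between 12000 nM and 120000 nM, with a real chance that it too is reported only as a limit.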

Compound 4, half-maximal inhibitory concentration: 23700 nM
The estimate for compound 4 lay 1.7-fold (0.23 log units) above the measured number; low and high end bracket the measured number.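

Adding a halogen to the phenyl group on this nitrogen does not by itself weaken inhibition in this assay: bromo in place of hydrogen gives a 1.1-fold higher number from compound 2 to compound 4 (0.03 log units; within the scatter), so 3-bromophenyl and plain phenyl cannot be told apart here. Exchanging 2-chlorophenyl for 3-bromophenyl at the same place, by contrast, gives an at least 2.1-fold lower number from compound 3 to compound 4 (0.32 log units; beyond the scatter), so the earlier drop on adding chloro does not hold for every halogen-bearing phenyl. The value of compound 3 is a limit and not a number, so this last step has only a floor and its full size stays unknown: the limit of > 50000 nM in this assay, at which 2 of the 4 values shown sit.

Compound 3 and compound 4 differ in both the halogen and its place on the ring, so these compounds cannot show which of the two changes matters. They also leave open whether a phenyl carrying an amine or a carboxylic acid instead of a halogen would give stronger inhibition than plain phenyl does, or whether any group on this nitrogen could do so.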